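Swapping Thiophen-3-yl for Thiophen-2-yl on the Shared Core

The source may hold more compounds than are shown below. What is called first, only, known or untested is meant among the compounds shown, and "the series" means these compounds.

Going by the values given here, in a functional assay on A-375 cells (Homo sapiens) for activation, with a stated time of 3 days (on this read-out higher numbers stand for an effect only at larger amounts of compound and lower numbers for an effect already at smaller amounts), only two compounds have numbers so far. Compound 1 (`O=C(Nc1ccc(-c2ccccn2)cc1)C1CCCN(Cc2ccc(F)c(F)c2)C1`) gives 11000 nM and compound 2 (`O=C(Nc1ccc(-c2ccsc2)cc1)C1CCCN(Cc2ccc(F)c(F)c2)C1`) gives 1930 nM as the lower of the two numbers. The next compound, compound 3 (`O=C(Nc1ccc(-c2cccs2)cc1)C1CCCN(Cc2ccc(F)c(F)c2)C1`), keeps the shared core and carries thiophen-2-yl in place of thiophen-3-yl on an aromatic carbon. The two have the same atoms, joined differently.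

Among the compounds with values here, the only measured step that bears on this change is a 5.7-fold lower number from compound 1 to compound 2 (0.76 log units; beyond the scatter) with thiophen-3-yl in place of pyridin-2-yl, which is modest and beyond the scatter. That step shows that a change at this place can move the number in this assay but it exchanged two different rings. Within the data shown here, no measured pair compares the two thiophene attachments, so the data offer no firm direction. A step beyond the scatter is therefore not expected. The step expected is a 1.2-fold higher number from compound 2 to compound 3 (0.09 log units; within the scatter) and it is only an estimate. For compound 3 the estimate is 2400 nM with an expected range from 950 nM to 6000 nM on this read-out.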

Compound 3, half-maximal effective concentration: 530 nM
Compound 3: middle estimate off by 4.5-fold (0.66 log units), on the high side; measured number below the stated range.
By their numbers in this assay, from the lowest: compound 3; then compound 2; then compound 1.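

In this assay the two thiophene compounds have the same atoms, joined differently, yet the change of attachment alone gives a 3.6-fold lower number from compound 2 to compound 3 (0.56 log units; beyond the scatter). This shows that at this place, on an aromatic carbon para to a large group, the number depends on how the ring is attached and not only on which ring stands there, something the earlier step between two different rings could not show. Measured against the pyridin-2-yl compound, the new ring gives a 21-fold lower number from compound 1 to compound 3 (1.32 log units; beyond the scatter), which leaves compound 3 with the lowest number of the three, and nothing available accounts for the difference between the two thiophene attachments.

The compounds shown leave open whether furan-2-yl, with oxygen in the place of sulfur, would follow thiophen-2-yl or thiophen-3-yl, and whether a methyl group on the thiophen-2-yl ring would move the number further in either direction. From the compounds shown here alone, all three also keep the rest of the shared core unchanged, so it remains open whether the difference between the two thiophene attachments would persist with a different group elsewhere on the core, such as an amine.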